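This account rests on a few compounds, and the source may have more. Where it says the series, first, only, none or still open, it means among the compounds named here.

Compound 1, `O=C(/C=C\Nc1ccc(F)cc1)c1nc(-c2ccc(C(F)(F)F)cc2)n2ccccc12`: > 30000 nM
Compound 2, `COc1ccc(N/C=C\C(=O)c2nc(-c3ccc(F)cc3)n3ccccc23)cc1OC`: > 30000 nM
Compound 3, `O=C(/C=C\Nc1cnc2ccccc2c1)c1nc(-c2ccc(C(F)(F)F)cc2)n2ccccc12`: > 30000 nM

In a functional assay on A549 cells (Homo sapiens) for cytotoxicity, read by MTT assay, with a stated time of 48 h (on this read-out higher numbers stand for weaker inhibition and lower numbers for stronger inhibition), compound 1 gives > 30000 nM, which is a limit of the assay rather than a measured number. Compound 2 likewise reaches only a limit, > 30000 nM. Compound 3 also stops at a limit, > 30000 nM. Within the data shown here, the single one-place step, a step that the two limits leave unreadable from compound 1 to compound 3, therefore cannot be read. Compound 4, `COc1ccc(-c2nc(C(=O)/C=C\Nc3ccc(F)cc3)c3ccccn23)cc1`, is not yet measured; it differs from compound 1 by methoxy in place of trifluoromethyl on an aromatic carbon. Among the measured compounds shown here, no measured step touches this change, and every value so far sits at the limit of > 30000 nM in this assay, at which 3 of the 3 values shown sit. Because of the limit of > 30000 nM in this assay, at which 3 of the 3 values shown sit, no size or direction can be set for the change. Compound 4 is expected to give about 40000 nM, in a range from 15000 nM to 150000 nM, most likely again as a limit. The step is expected to be a step that the limit leaves unreadable from compound 1 to compound 4.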

Compound 4, half-maximal inhibitory concentration: > 30000 nM
Compound 4: no number, only a limit; the forecaster's own chance of this, stated with the estimate: 80%; the middle value is on the limit's open side.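

The step from compound 1 to compound 4 cannot be read, because both compounds stop at a limit rather than a number: the limit of > 30000 nM in this assay, at which 4 of the 4 values shown sit.

The compounds shown leave open whether swapping trifluoromethyl for methoxy changes the read-out in this assay at all.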